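Bromine in Place of Hydroxy on a Shared Core

A few compounds are considered here, and "the series" means these few. Any claim that something is new, unique, unknown or untested is made for them only; others in the source may bear on it.

Of the compounds shown here, three sharing one core have been measured in an assay on HT-29 cells with Methylated-DNA--protein-cysteine methyltransferase (Homo sapiens) as the target, with a stated time of 30 min; on this read-out higher numbers stand for an effect only at larger amounts of compound and lower numbers for an effect already at smaller amounts. Compound 1 `Nc1nc(OCc2ccccc2)c2[nH]c(N)nc2n1` gives 0.7 uM. Compound 2 `Cc1nc2[nH]c(N)nc(OCc3ccccc3)c-2n1` gives 0.3 uM, and compound 3 `Nc1nc(OCc2ccccc2)c2[nH]c(O)nc2n1` gives 0.3 uM. Among the compounds with values here, the only single-point step recorded, a 2.3-fold lower number from compound 1 to compound 3 (0.37 log units; beyond the scatter), is a modest one. Compound 3 stands level with compound 2 at the digits shown, and together they carry the lowest numbers of the three. Compound 4 `Nc1nc(OCc2ccccc2)c2[nH]c(Br)nc2n1` differs from compound 3 by bromo in place of hydroxy on an aromatic carbon. Within the data shown here, no measured step exchanges a hydroxy for a halogen, so the only guide is that the one change already made at that carbon gave a modest step. A small shift is expected, a 2.0-fold higher number from compound 3 to compound 4 (0.30 log units; within the scatter), so compound 4 is estimated at 0.6 uM with a range from 0.2 uM to 2 uM.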

Compound 4, concentration for half-maximal effect: 0.08 uM
Beside the measured number, compound 4's estimate is 7.5-fold (0.88 log units) above it; the whole stated range lies above it.
By their numbers in this assay, from the lowest: compound 4; then compounds 2 and 3 (each within the scatter of the next); then compound 1.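

At this carbon of the shared core, bromo in place of hydroxy gives a 3.8-fold lower number from compound 3 to compound 4 (0.57 log units; beyond the scatter) in this assay, and bromo in place of amino gives an 8.8-fold lower number from compound 1 to compound 4 (0.94 log units; beyond the scatter). The hydrogen-bond donor and acceptor counted on hydroxy are therefore not required here, since bromo has neither and still gives the lowest number of the set. No available evidence explains why bromo gives this result. Going by these compounds, whether chlorine or iodine would match bromo at this carbon remains open. So does how a carboxylic acid would fare there.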